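Catechol O-methyltransferase inhibitors: furan-2-yl to 1,3-thiazol-2-yl swap

This account rests on a few compounds, and the source may have more. Where it says the series, first, only, none or still open, it means among the compounds named here.

Measured so far:
compound 1 `CC(=O)N1N=C(c2cc(O)c(O)c([N+](=O)[O-])c2)CC1c1ccco1`: 180 nM
compound 2 `O=C(/C=C/c1cccc(O)c1)c1cc(O)c(O)c([N+](=O)[O-])c1`: 140 nM

In an assay for inhibition of Catechol O-methyltransferase (Rattus norvegicus), read by fluorescence and spectrophotometry (on this read-out lower numbers stand for stronger inhibition and higher numbers for weaker inhibition), compound 1 gives 180 nM and compound 2 gives 140 nM; the two numbers lie within the scatter of each other, so compound 1 does not stand apart from compound 2. For the measured compounds named here, no step between measured compounds is available.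

Compound 3 `CC(=O)N1N=C(c2cc(O)c(O)c([N+](=O)[O-])c2)CC1c1nccs1` is not yet measured. It differs from compound 1 by 1,3-thiazol-2-yl in place of furan-2-yl on a saturated ring carbon. Going by the values given here, with no comparable step in hand, the expected change is none beyond the scatter, in either direction. Compound 3 is therefore expected to give about 200 nM, in a range of 70 nM to 600 nM, a step of a 1.1-fold higher number from compound 1 to compound 3 (0.05 log units; within the scatter) in this assay.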

Compound 3, half-maximal inhibitory concentration: 160 nM
Beside the measured number, compound 3's estimate is 1.3-fold (0.10 log units) above it; low and high end bracket the measured number.
By their numbers in this assay, from the lowest: compounds 2, 3 and 1 (each within the scatter of the next).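

In this assay, 1,3-thiazol-2-yl in place of furan-2-yl on the saturated ring carbon gives a 1.1-fold lower number from compound 1 to compound 3 (0.05 log units; within the scatter), the first step read at this position. This position therefore accepts either five-membered aromatic ring, and the additional hydrogen-bond acceptor counted for 1,3-thiazol-2-yl brings no change beyond the scatter. Nothing available explains why the two rings read alike. Open, from the compounds shown here alone, is whether a phenyl ring, a cyclohexyl group or an aminomethyl group at this carbon would hold the number. Also open, going by these compounds, is whether a longer acyl chain could replace the acetyl group.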